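The source may hold more compounds than are shown below. What is called first, only, known or untested is meant among the compounds shown, and "the series" means these compounds.

Measured in a functional assay on A-375 cells (Homo sapiens) for antiproliferative activity, read by MTT assay, with a stated time of 72 h; a lower number here means a stronger inhibitor, a higher number a weaker inhibitor:
- compound 1, `O=C1COc2ccc(-c3ccc(O)cc3)cc2N1`: > 40000 nM, a limit of the assay
- compound 2, `O=C1COc2ccc(-c3cnc4ccccc4c3)cc2N1c1ccc(Cl)cc1`: > 40000 nM, a limit of the assay
- compound 3, `CC(C)N1C(=O)COc2ccc(-c3cccc(NS(=O)(=O)c4ccc(F)cc4)c3)cc21`: > 40000 nM, a limit of the assay

Compound 3 stands at a limit of this assay, so no number is known for it. The same holds for everything else shown here, since (the limit of > 40000 nM in this assay, at which 3 of the 3 values shown sit). Going by the values given here, no pair of measured compounds differs in one place, and no measured step gives a size to lean on.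

Compound 4 is `Cc1ccc(N2C(=O)COc3ccc(-c4cccc(NS(=O)(=O)c5ccc(F)cc5)c4)cc32)cc1`. It differs from compound 3 in one place: 4-methylphenyl in place of isopropyl on an amide-type nitrogen in a ring. Among the compounds with values here, nothing measured ties this change to a change in potency, so the expectation for the step from compound 3 to compound 4 in this assay is none beyond the scatter, and the estimate simply stays at the limit where the series so far sits. Compound 4 is expected to give about 40000 nM, within 10000 nM to 120000 nM, most likely reported again only as a limit. The expected step of a number no higher from compound 3 to compound 4 (the limit leaves the size open) is therefore none beyond the scatter.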

Compound 4, half-maximal inhibitory concentration: 36200 nM
For compound 4 the middle estimate is 1.1-fold (0.04 log units) above the measured one, within the range that was stated.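

On the amide-type nitrogen in a ring, 4-methylphenyl in place of isopropyl gives in this assay an at least 1.1-fold lower number from compound 3 to compound 4 (0.04 log units; that floor lies within the scatter). Going by these compounds alone, compound 4 gives 36200 nM, the only value shown that is a number and not a limit, so this nitrogen carries an aromatic ring with a readable result, though nothing here separates compound 4 from compound 3 beyond the scatter. The step has only a floor and no true size because its starting point is a limit: the limit of > 40000 nM in this assay, at which 3 of the 4 values shown sit.

Going by these compounds, whether a substituent on the 4-methylphenyl ring, such as an amine or a carboxylic acid, would shift the value on this nitrogen remains open. A longer alkyl chain in the same place is equally untested by the compounds shown, so no trend with the size of this group can be stated.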